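Adding a Hydroxy Group and Oral Exposure in Mice

The compounds below may be only part of what the source reports. "The series", "measured", "known", "first", "only" and "open" are said of these compounds alone.

Compound 1 `CC1=C(c2cccc(C#N)c2)C(c2ccc(OC[C@H](C)N3CC[C@@H](C)C3)cc2)Oc2ccc(O)cc21` was not measured for exposure: in an ADME assay on the whole organism for pharmacokinetics, with Mus musculus as the target, at a dose of 10 mg/kg by the oral route (on this read-out higher numbers stand for higher exposure at the dose given and lower numbers for lower exposure), compound 1 gives "not determined" (no result reported), so no number exists for it. Among the measured compounds shown here, compound 2 `CC1=C(c2ccccc2)C(c2ccc(OC[C@H](C)N3CC[C@@H](C)C3)cc2)Oc2ccc(O)cc21` is therefore the only compound with a value: in this assay compound 2 gives 1000 ng.h/mL. It stands alone, with nothing measured to set beside it. Compound 3 `CC1=C(c2ccc(O)cc2)C(c2ccc(OC[C@H](C)N3CC[C@@H](C)C3)cc2)Oc2ccc(O)cc21` differs from compound 2 in one place: hydroxy in place of hydrogen on an aromatic carbon. For the measured compounds named here, no measured pair shows what such a change does to exposure here, so the expectation rests on the change itself and on the single value of compound 2. Compound 3 is expected to show somewhat lower exposure in this assay, a step of a 2.0-fold lower number from compound 2 to compound 3 (0.30 log units; within the scatter) that is judged to sit around the edge of the usual scatter rather than clearly beyond it. Compound 3 is accordingly estimated at 500 ng.h/mL, with a range from 150 ng.h/mL to 1500 ng.h/mL.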

Compound 3, area under the concentration-time curve: 460 ng.h/mL
For compound 3 the middle estimate is 1.1-fold (0.04 log units) above the measured one, within the range that was stated.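

In this assay, among the compounds shown here, going from phenyl to 4-hydroxyphenyl gives a 2.2-fold lower number from compound 2 to compound 3 (0.34 log units; beyond the scatter) as the first measured pair here, showing that exposure responds to a change at this place on the ring, para to a large group. The step is modest, and one pair on one read-out sets no rule for hydroxy groups elsewhere on these compounds. Nothing shown here bears on why the number falls.

Still open, going by these compounds, is whether this lower exposure is tied to hydroxy or would also follow other groups at the same aromatic carbon, such as methoxy, an amine or a carboxylic acid. The compounds shown also leave open how hydroxy would behave at another carbon of the same ring.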